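Methoxy in place of acetamido on the aryl triazole

A few compounds are considered here, and "the series" means these few. Any claim that something is new, unique, unknown or untested is made for them only; others in the source may bear on it.

Compound 3 `CC(=O)Nc1ccc(-n2nncc2CN2C(=O)C3(C(C#N)=C(N)Oc4c(N)cc5nc6ccccc6nc5c43)c3ccccc32)cc1` stands at a limit in a functional assay on A549 cells (Homo sapiens) for antiproliferative activity, read by MTT assay, with a stated time of 48 h; a lower number here means a stronger inhibitor, a higher number a weaker inhibitor: compound 3 gives > 50000 nM, a limit rather than a number. Compound 1 `N#CC1=C(N)Oc2c(N)cc3nc4ccccc4nc3c2C12C(=O)N(Cc1cnnn1-c1ccc(Cl)cc1)c1ccccc12` likewise gives only a limit, > 50000 nM. Compound 2 `N#CC1=C(N)Oc2c(N)cc3nc4ccccc4nc3c2C12C(=O)N(Cc1cnnn1-c1cccc(Br)c1)c1ccccc12` gives 18900 nM. Compound 4 `COc1ccc(-n2nncc2CN2C(=O)C3(C(C#N)=C(N)Oc4c(N)cc5nc6ccccc6nc5c43)c3ccccc32)cc1` differs from compound 3 by methoxy in place of acetamido on an aromatic carbon. The steps that touch the same aryl group are an at least 2.6-fold lower number from compound 1 to compound 2 (0.42 log units; beyond the scatter) and an at least 2.6-fold higher number from compound 2 to compound 3 (0.42 log units; beyond the scatter); the step that the two limits leave unreadable from compound 1 to compound 3 cannot be read. Both compounds carrying a group para to a large group on that phenyl stand at the limit described by the limit of > 50000 nM in this assay, at which 2 of the 3 values shown sit, so compound 4 is expected to stay close to it, with an at least 1.1-fold lower number from compound 3 to compound 4 (0.04 log units; that floor lies within the scatter) as the estimated step. Compound 4 is expected to give 45000 nM, within 15000 nM to 150000 nM.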

Compound 4, half-maximal inhibitory concentration: > 50000 nM
Compound 4: a limit, no number; the forecaster's own chance of this, stated with the estimate: 60%; middle value at least 1.1-fold (0.04 log units) from the limit.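

In this assay compound 4 gives > 50000 nM, a limit and not a number. With methoxy in place of acetamido, para to a large group, the compound gives no readable value either, and the steps from compound 3 to compound 4 and from compound 1 to compound 4 cannot be read. The change from 3-bromophenyl to 4-methoxyphenyl gives an at least 2.6-fold higher number from compound 2 to compound 4 (0.42 log units; beyond the scatter), and the limit is now the most common result: the limit of > 50000 nM in this assay, at which 3 of the 4 values shown sit.

As far as these compounds go, it remains open whether an amine or a carboxylic acid at this place would give a measurable value. From the compounds shown here alone, how far compound 1, compound 3 and compound 4 differ from one another also stays unknown.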